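Shortening the Side Chain: From Compound 2 to Compound 3

The source may report more compounds than this note shows. Statements on the series, on what has been measured and on what is new or still open speak of the compounds shown alone.

Compound 1 `CC(C)[C@H](NC(=O)CN(c1nc(Cl)nc2[nH]cnc12)C1CC1)C(=O)O` and compound 2 `CSCC[C@H](NC(=O)CN(c1nc(Cl)nc2[nH]cnc12)C1CC1)C(=O)O` share one core and differ only in a side chain. In a functional assay on the whole organism (Tail, strain ICR) with Mus musculus as the target, in the tail flick test, with a stated time of 60 min, at a dose of 25 umol/kg by the oral route (on this read-out higher numbers stand for a stronger effect at the one dose given and lower numbers for a weaker effect), compound 1 gives 38.8%, while compound 2 gives 22.8%, the lower of the two numbers. Going by the values given here, the one measured step, a number 16 percentage points lower from compound 1 to compound 2 (beyond the scatter), concerns a different exchange and so gives only loose guidance. Compound 3 `C[C@H](NC(=O)CN(c1nc(Cl)nc2[nH]cnc12)C1CC1)C(=O)O` differs from compound 2 by hydrogen in place of (methylsulfanyl)methyl on a saturated chain carbon, two bonds along the chain from an amide-type nitrogen and a carbonyl carbon. Because of the drop in a number 16 percentage points lower from compound 1 to compound 2 (beyond the scatter), compound 3 is expected to shift by a number 7.2 percentage points higher from compound 2 to compound 3 (within the scatter), back toward compound 1 rather than lower. Compound 3 is therefore estimated at 30%, within 12% to 50%.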

Compound 3, a percentage reported as activity, at one dose (the size of the read-out at that dose, not a potency): 44.6%
Estimate against measurement, compound 3: 14.6 percentage points below, within the range that was stated.
By their numbers in this assay, from the lowest: compound 2; then compounds 1 and 3 (each within the scatter of the next).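

In this assay, hydrogen in place of (methylsulfanyl)methyl gives a clear gain (a number 21.8 percentage points higher from compound 2 to compound 3 (beyond the scatter)), so a chain that carries sulfur is not needed here for the effect. Methyl and isopropyl cannot be told apart at this position (a number 5.8 percentage points higher from compound 1 to compound 3 (within the scatter)), which leaves compound 2 as the only one of the three that stands apart. Nothing measured here explains this pattern. As far as these compounds go, it remains open whether the lower number of compound 2 comes from its sulfur atom or from its chain length. A plain butyl chain could separate the two, while a side chain ending in an amine or a carboxylic acid is a further untested type of group.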